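The source may report more compounds than this note shows. Statements on the series, on what has been measured and on what is new or still open speak of the compounds shown alone.

Of the compounds shown here, two have so far been measured in an assay on isolated protein for inhibition of tyrosine-protein phosphatase non-receptor type 13 (Homo sapiens), read by spectrophotometry; a higher number here means a weaker inhibitor, a lower number a stronger inhibitor. Compound 1 `O=C(COc1ccc2cc(C(O)(C(F)(F)F)C(F)(F)F)c(O)cc2c1)Nc1nc2ccccc2s1` gives 9900 nM, while compound 2 `Oc1c(-c2ccccc2)cccc1C(O)(C(F)(F)F)C(F)(F)F` gives 449000 nM. Of these two numbers, compound 1 holds the lower one, and its distance from compound 2 lies well beyond the usual scatter, so compound 1 is the stronger inhibitor of the pair. Compound 3 `CC(C)c1ccc(NC(=O)COc2ccc3cc(C(O)(C(F)(F)F)C(F)(F)F)c(O)cc3c2)cc1` has not yet been tested in this assay. It keeps the core of compound 1 and differs from it in a single place: 4-isopropylphenyl in place of 1,3-benzothiazol-2-yl on an amide-type nitrogen. For the measured compounds named here, no measured pair of compounds shows this particular change, so its effect cannot be read from the data at hand. Compound 3 is therefore expected to land near compound 1, most likely a small step toward a weaker inhibitor, possibly still within the scatter. The estimate for compound 3 in this assay is 16000 nM, with a range from 4000 nM to 65000 nM. This estimate corresponds to an expected step of a 1.6-fold higher number from compound 1 to compound 3 (0.21 log units; within the scatter).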

Compound 3, half-maximal inhibitory concentration: 6500 nM
Estimate against measurement, compound 3: 2.5-fold (0.39 log units) above; measured number inside the range.
By their numbers in this assay, from the lowest: compounds 3 and 1 (each within the scatter of the next); then compound 2.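

In this assay, putting 4-isopropylphenyl in place of 1,3-benzothiazol-2-yl on the amide-type nitrogen gives a 1.5-fold lower number from compound 1 to compound 3 (0.18 log units; within the scatter) and stays within the usual scatter. This first step at this position shows that, in this one pair, the place accepts a single carbon-only aromatic ring with no hydrogen-bond acceptors in place of a two-ring group with hetero atoms and hydrogen-bond acceptors, without any change that can be read. Nothing measured here explains why the swap leaves the number within the scatter. What the compounds shown leave open is whether this tolerance extends to groups of another kind on that nitrogen, such as a carboxylic acid, an amine or a longer alkyl chain. They also leave open whether the 4-isopropyl group itself matters, as against a plain phenyl ring.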